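This account rests on a few compounds, and the source may have more. Where it says the series, first, only, none or still open, it means among the compounds named here.

In a functional assay on HT-29 cells (Homo sapiens) for antiproliferative activity, read by sulforhodamine B assay, with a stated time of 48 h (a lower number here means a stronger inhibitor, a higher number a weaker inhibitor), compound 1 (`COc1cccc(OS(=O)(=O)c2ccc(N3CCN(C)C3=O)cc2)c1`) gives 2500 nM and compound 2 (`CN1CCN(c2ccc(S(=O)(=O)Oc3cccc(Br)c3)cc2)C1=O`) gives 1300 nM. On these numbers, compound 2 stands level with compound 1, and the two cannot be ranked. Compound 3 (`CN1CCN(c2ccc(S(=O)(=O)Oc3ccc(F)cc3)cc2)C1=O`) departs from compound 2 at a single place, with 4-fluorophenyl in place of 3-bromophenyl on an oxygen. Going by the values given here, the one measured step bears on this change only loosely, as it concerns a different exchange: a 1.9-fold lower number from compound 1 to compound 2 (0.28 log units; within the scatter). Among the compounds with values here, no measured compound carries 4-fluorophenyl, so the expectation rests on that small step alone. No step beyond the scatter is therefore expected in this assay, and no direction can be firmly called. The estimated step is a 1.5-fold higher number from compound 2 to compound 3 (0.19 log units; within the scatter). For compound 3, the expected value is 2000 nM, with an estimated range of 700 nM to 6000 nM.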

Compound 3, half-maximal inhibitory concentration: > 100000 nM
Compound 3 was reported as a limit; the forecaster's own chance of this, stated with the estimate: 8%; middle value at least 50-fold (1.69 log units) from the limit.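

Compound 3 gives > 100000 nM in this assay, which is a limit of the assay and not a number. The exchange of 3-bromophenyl for 4-fluorophenyl brings an at least 76-fold higher number from compound 2 to compound 3 (1.88 log units; beyond the scatter), and the exchange of 3-methoxyphenyl for 4-fluorophenyl brings an at least 40-fold higher number from compound 1 to compound 3 (1.60 log units; beyond the scatter). Compound 1 and compound 2 could not be ranked, but the group on the oxygen bound to the sulfonyl sulfur now proves able to carry a large step in this assay.

The change in compound 3 alters both the atom on the aromatic ring and its place on that ring, and the compounds shown do not tell which of the two carries the step. From the compounds shown here alone, it also stays open how 3-fluorophenyl, 4-bromophenyl or 3-aminophenyl would stand at this position.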